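Series notes: methyl position on the pendant phenyl

The source may report more compounds than this note shows. Statements on the series, on what has been measured and on what is new or still open speak of the compounds shown alone.

Compound 1 `CCCS(=O)(=O)Nc1ccc(F)c(C(=O)c2n[nH]c3ncc(-c4ccccc4)cc23)c1F`: 2.4%
Compound 2 `CCCS(=O)(=O)Nc1ccc(F)c(C(=O)c2n[nH]c3ncc(-c4ccccc4F)cc23)c1F`: 2%
Compound 3 `CCCS(=O)(=O)Nc1ccc(F)c(C(=O)c2n[nH]c3ncc(-c4cccc(C)c4)cc23)c1F`: 15%

In an assay for binding affinity to dual specificity mitogen-activated protein kinase kinase 4 (Homo sapiens), read by KINOMEscan, tested at 100 nM (a lower number here means a stronger effect, a higher number a weaker effect of the compound at the concentration tested), compound 3 stands highest of the three numbers, with compound 1 nearer and compound 2 further below it. The steps of a number 12.6 percentage points higher from compound 1 to compound 3 (beyond the scatter) and a number 13 percentage points higher from compound 2 to compound 3 (beyond the scatter) are both modest and beyond the scatter, whereas a number 0.4 percentage points lower from compound 1 to compound 2 (within the scatter) lies within it. Compound 4 `CCCS(=O)(=O)Nc1ccc(F)c(C(=O)c2n[nH]c3ncc(-c4ccc(C)cc4)cc23)c1F` differs from compound 3 as follows: 4-methylphenyl in place of 3-methylphenyl on an aromatic carbon. Going by the values given here, no measured step exchanges a 3-methylphenyl for a 4-methylphenyl, so the two steps that bring in the methyl are the only guide, and they do not say whether the 4-methylphenyl will sit near compound 3 or near the phenyl of compound 1. A step of a number 6 percentage points lower from compound 3 to compound 4 (within the scatter) toward lower numbers is therefore expected, of at most the size seen on adding the methyl. Compound 4 is estimated at 9% in this assay, between 2% and 22%.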

Compound 4, a percentage reported as activity, at one concentration (the size of the read-out at that concentration, not a potency): 5.4%
Estimate against measurement, compound 4: 3.6 percentage points above; the measured number falls inside the stated range.
By their numbers in this assay, from the lowest: compounds 2, 1, 4 and 3 (each within the scatter of the next, the first and the last beyond it).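

In this assay the shift from 3-methylphenyl to 4-methylphenyl gives a number 9.6 percentage points lower from compound 3 to compound 4 (within the scatter) and so cannot be told apart from the scatter. Unlike a number 12.6 percentage points higher from compound 1 to compound 3 (beyond the scatter), which lies beyond the scatter, a number 3 percentage points higher from compound 1 to compound 4 (within the scatter) and a number 3.4 percentage points higher from compound 2 to compound 4 (within the scatter) both lie within it, so a methyl on the pendant phenyl does not give a step beyond the scatter in both placements shown. The data offer no explanation for this difference between the two steps that add the methyl. Still open, from the compounds shown here alone, is how an amine or a carboxylic acid in place of the methyl of compound 4 would read, and whether a longer chain there would keep the number within the scatter of compound 1.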